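Clearance notes on carbinol aryl replacement in the series

A few compounds are considered here, and "the series" means these few. Any claim that something is new, unique, unknown or untested is made for them only; others in the source may bear on it.

Measured so far:
- Compound 1 `COc1cc([C@](O)(CCN(C)C)[C@@H](c2cc3cc(C#N)ccc3nc2OC)c2cccc(C)c2F)cc(OC(F)F)n1`: 0.6 uL/min
- Compound 2 `COc1cc([C@](O)(CCN(C)C)[C@@H](c2cc3cc(C#N)ccc3nc2OC)c2ccnc(OC)c2OC)cc(OC(F)F)n1`: 2.5 uL/min

In an ADME assay on microsomes from liver (Homo sapiens) for metabolic stability (on this read-out lower numbers stand for slow clearance and higher numbers for fast clearance), compound 1 gives 0.6 uL/min, the lowest of the two numbers; compound 2 sits a 4.2-fold higher number from compound 1 to compound 2 (0.62 log units; beyond the scatter). Compound 3 `COc1nc2ccc(C#N)cc2cc1[C@@H](c1cccc(C)c1F)[C@@](O)(CCN(C)C)c1cc(SC)nc(SC)c1` carries a group of 10 heavy atoms (7 carbon, 1 nitrogen, 2 sulfur; one six-membered aromatic ring with 1 hetero atom) in place of a group of 12 heavy atoms (7 carbon, 1 nitrogen, 2 oxygen, 2 fluorine; one six-membered aromatic ring with 1 hetero atom), on a saturated chain carbon bound to an oxygen on a saturated carbon and two saturated chain carbons. For the measured compounds named here, the only measured step alters the other aryl group, not this position, so it does not bear on the change directly; it shows only that one aryl swap moved clearance modestly. Compound 3 is therefore expected to show a 2.5-fold higher number from compound 1 to compound 3 (0.40 log units; beyond the scatter), a small rise with wide uncertainty. The estimate for compound 3 is 1.5 uL/min, ranging from 0.5 uL/min to 5 uL/min.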

Compound 3, intrinsic clearance in a liver preparation (reported as CLH), per the amount of preparation that the assay uses: 9.2 uL/min
Compound 3: middle estimate off by 6.1-fold (0.79 log units), on the low side, and the stated range ends below it.
By their numbers in this assay, from the lowest: compound 1; then compound 2; then compound 3.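

This position is not silent: in this assay the group of 10 heavy atoms with 2 sulfur gives a 15-fold higher number from compound 1 to compound 3 (1.19 log units; beyond the scatter) on the core of compound 1, a large step, whereas the earlier step concerned a different aryl group. Clearance therefore responds strongly to the aryl group on this carbon. Nothing available accounts for the rise.

Open, from the compounds shown here alone, is whether the sulfur atoms or the loss of the oxygen and fluorine atoms carries the step. A group with one methylthio and one difluoromethoxy, or a methylsulfonyl group, would separate these.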